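The source may hold more compounds than are shown below. What is called first, only, known or untested is meant among the compounds shown, and "the series" means these compounds.

Going by the values given here, in a functional assay on HeLa cells (Homo sapiens) for inhibition, read by cell counting, with a stated time of 4 days (a lower number here means a stronger inhibitor, a higher number a weaker inhibitor), compound 2 `COc1ccc(Nc2nc(C)nc3c2nc(C)n3C)cc1` gives 197000 nM, the higher of the two numbers so far, and so the weaker inhibitor of the pair. Compound 1 `COc1ccc(N(C)c2nc(C)nc3c2nc(C)n3C)cc1` gives 4500 nM. Compound 3 `CCN(c1ccc(OC)cc1)c1nc(C)nc2c1nc(C)n2C` differs from compound 2 by ethyl in place of hydrogen on a nitrogen on an aromatic ring, with ethyl in place of hydrogen on a nitrogen on an aromatic ring. Among the compounds with values here, the one measured step that bears on this is large: a 44-fold higher number from compound 1 to compound 2 (1.64 log units; beyond the scatter), at that same nitrogen, with hydrogen in place of methyl. Ethyl is not methyl, so only most of that large step is expected back, as a clear fall in the number in this assay. The expected change is a 22-fold lower number from compound 2 to compound 3 (1.34 log units; beyond the scatter). Compound 3 is estimated at 9000 nM, within a range of 2500 nM to 40000 nM.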

Compound 3, half-maximal inhibitory concentration: 20000 nM
Beside the measured number, compound 3's estimate is 2.2-fold (0.35 log units) below it; low and high end bracket the measured number.
By their numbers in this assay, from the lowest: compound 1; then compound 3; then compound 2.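

Putting ethyl on this nitrogen also lowers the number, giving a 9.9-fold lower number from compound 2 to compound 3 (0.99 log units; beyond the scatter), so the gain from replacing the hydrogen is not confined to methyl. Ethyl does not match methyl, however, with a 4.4-fold higher number from compound 1 to compound 3 (0.65 log units; beyond the scatter), so the number depends on which group sits here and not only on the hydrogen being gone. Nothing available explains either step. Still open, going by these compounds, is whether a longer chain such as propyl on this nitrogen would raise the number further, and how a chain ending in an amine or a carboxylic acid would behave.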